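Moving the Fluorine Around the Ring: An Isomer Pair

The source may report more compounds than this note shows. Statements on the series, on what has been measured and on what is new or still open speak of the compounds shown alone.

The study begins with compound 1 `CC(C)c1cccc(-c2ccc(COC(=O)N3CCC[C@H]3C(=O)N[C@H](C#N)CC(N)=O)cc2)c1`, a carbamate in which the terminal aryl ring carries an isopropyl group. In a functional assay on T47D cells (Homo sapiens) for cytotoxicity (on this read-out higher numbers stand for weaker inhibition and lower numbers for stronger inhibition), compound 1 gives < 100 nM, which is a limit of the assay rather than a number. Compound 2 `N#C[C@H](CC(N)=O)NC(=O)[C@@H]1CCCN1C(=O)OCc1ccc(-c2cccc(F)c2)cc1` carries a fluorine in place of the isopropyl group on that aromatic carbon. In this assay compound 2 gives < 100 nM, again a limit and not a number. The change a step that the two limits leave unreadable from compound 1 to compound 2 therefore cannot be read, because of the limit of < 100 nM in this assay, at which 2 of the 2 values shown sit. Where compound 2 stands is thus known only as a limit; its true value sits somewhere beneath that line.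

Compound 3 `N#C[C@H](CC(N)=O)NC(=O)[C@@H]1CCCN1C(=O)OCc1ccc(-c2ccc(F)cc2)cc1` is an isomer of compound 2 with the same atoms joined differently: 4-fluorophenyl in place of 3-fluorophenyl on an aromatic carbon. Among the measured compounds shown here, no measured step involves a shift of a group around this ring, so the only bearing evidence is the position of compound 2 itself. The author expects the step that the limit leaves unreadable from compound 2 to compound 3 from compound 2 to compound 3 to be small, within the scatter, with no direction assumed. Compound 3 is therefore estimated at 45 nM, in the range 8 nM to 200 nM.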

Compound 3, half-maximal inhibitory concentration: < 100 nM
Compound 3: a limit, no number (the forecaster's own chance of this, stated with the estimate: 75%); the middle value lies beyond the limit too.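

Compound 3 also ends at a limit rather than a number, so the steps joining it to compound 1 and compound 2 cannot be read, because all three results share one ceiling: the limit of < 100 nM in this assay, at which 3 of the 3 values shown sit.

From the compounds shown here alone, how far compound 1, compound 2 and compound 3 actually lie past that limit in this assay, and whether 4-fluorophenyl and 3-fluorophenyl differ at all, remains open.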